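Sulfonamide series: tolerance on kidney cells, next step

A few compounds are considered here, and "the series" means these few. Any claim that something is new, unique, unknown or untested is made for them only; others in the source may bear on it.

Compound 1 `O=S(=O)(Nc1ccc2oc(-c3ccccc3)nc2c1)c1cccc(F)c1` is the reference point of the set. In an ADME assay on HEK293 cells (Homo sapiens) for cytotoxicity, read by resazurin assay, with a stated time of 48 h (a higher number here means that more compound is tolerated, a lower number that less compound is tolerated), compound 1 gives 68000 nM, the only plain number shown so far. Compound 2 `C=Cc1ccc(S(=O)(=O)Nc2ccc(-c3nc4ccccc4o3)cc2)cc1` stands differently in the read-out: in this assay compound 2 reaches only a limit of the assay, > 100000 nM, so no number can be placed against it. The set thus holds one number and one limit, (the limit of > 100000 nM in this assay, at which 1 of the 2 values shown sits).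

Compound 3 `O=S(=O)(Nc1ccc2oc(-c3ccccc3)nc2c1)c1ccc(O)cc1` is the next member and has not yet been measured in this assay. It differs from compound 1 in one place: 4-hydroxyphenyl in place of 3-fluorophenyl on a sulfonyl sulfur. For the measured compounds named here, no measured pair in the set shares this change, so the size of the step is open. For compound 3 the expected step is a 1.3-fold higher number from compound 1 to compound 3 (0.10 log units; within the scatter), within or just beyond the scatter, towards more tolerated rather than less. The estimate for compound 3 in this assay is 85000 nM, with a range from 40000 nM to 160000 nM.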

Compound 3, half-maximal cytotoxic concentration: > 100000 nM
Compound 3: a limit, no number; the forecaster's own chance of this, stated with the estimate: 35%; middle value at least 1.1-fold (0.07 log units) from the limit.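

Putting 4-hydroxyphenyl in place of 3-fluorophenyl on the sulfonyl sulfur gives, in this assay, an at least 1.4-fold higher number from compound 1 to compound 3 (0.16 log units; that floor lies within the scatter). For the compounds shown here, this is the first single-place change in the set that can be read, and it gives only a floor. Going by these compounds, compound 3 gives > 100000 nM, which is a limit and not a number, so the real size of the step remains unknown and a step within the scatter is not excluded. Values in the series now gather at the top of the read-out: the limit of > 100000 nM in this assay, at which 2 of the 3 values shown sit.

The compounds shown do not separate the loss of the fluorine from the arrival of the hydroxyl on the phenyl ring. On these data alone, it also remains open whether an amine or a carboxylic acid on that ring would stay at this limit or give a readable number.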